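The source may hold more compounds than are shown below. What is called first, only, known or untested is meant among the compounds shown, and "the series" means these compounds.

Measured compounds:

Compound 1, `Cc1nc(Nc2cccc(Cl)c2)sc1C(=O)/C=C/c1ccc(Cl)cc1`. In a functional assay on Bel-7402 cells (Homo sapiens) for cytotoxicity, read by MTT assay (a lower number here means a stronger inhibitor, a higher number a weaker inhibitor), compound 1 gives > 25000 nM, which is a limit of the assay and not a number.

Compound 2, `Cc1ccccc1Nc1nc(C)c(C(=O)/C=C/c2ccc(Cl)cc2)s1`. In this assay compound 2 gives > 25000 nM, again a limit of the assay.

Compound 3, `Cc1ccccc1Nc1nc(C)c(C(=O)/C=C/c2ccccc2)s1`. In this assay compound 3 gives > 25000 nM, also a limit of the assay.

Compound 2 therefore stands only at a limit, and the two other values shown for this series are limits as well; all three sit at the limit of > 25000 nM in this assay, at which 3 of the 3 values shown sit. The two measured steps, a step that the two limits leave unreadable from compound 1 to compound 2 and a step that the two limits leave unreadable from compound 2 to compound 3, can thus not be read in size, since both ends of each step lie at the same limit.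

Compound 4, `Cc1nc(Nc2ccccc2)sc1C(=O)/C=C/c1ccc(Cl)cc1`, has not yet been measured. It differs from compound 2 by hydrogen in place of methyl on an aromatic carbon, which one bond further out reads as 2-methylphenyl to phenyl. Both measured steps touch the outer rings of this scaffold without moving any compound off the limit, so nothing in the data points to a readable step in either direction for this assay. Compound 4 is therefore expected to remain at the limit, and the expected step that the limit leaves unreadable from compound 2 to compound 4 is one that the limit would leave unreadable. The estimate for compound 4 in this assay is 40000 nM, within a range of 12000 nM to 150000 nM.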

Compound 4, half-maximal inhibitory concentration: > 25000 nM
Compound 4: a limit, no number (the forecaster's own chance of this, stated with the estimate: 85%); the middle value is on the limit's open side.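

In this assay compound 4 gives > 25000 nM, which is a limit of the assay and not a number. Its steps from compound 1 and from compound 2 cannot be read in size, as all of these compounds sit at one limit: the limit of > 25000 nM in this assay, at which 4 of the 4 values shown sit.

The compounds shown leave open which change to the shared core, if any, would give a readable number in this assay.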